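From nitro to carboxy on a phenyl ring

A few compounds are considered here, and "the series" means these few. Any claim that something is new, unique, unknown or untested is made for them only; others in the source may bear on it.

- compound 1 `Cn1cncc1C(O)(c1ccc([N+](=O)[O-])cc1)c1cc2cc([N+](=O)[O-])cc(-c3ccccc3)c2o1` (547 nM)
- compound 2 `Cn1cncc1[C@@](N)(c1ccc(C#N)cc1)c1cc2cc(C#N)cc(-c3cccc(C#N)c3)c2o1` (2 nM)
- compound 3 `Cn1cncc1C(O)(c1ccc(C#N)cc1)c1cc2cc([N+](=O)[O-])cc(-c3ccc(F)cc3)c2o1` (158 nM)

All three values come from a functional assay on QG-56 cells (Homo sapiens) for antiproliferative activity; on this read-out lower numbers stand for stronger inhibition and higher numbers for weaker inhibition. Compound 1 has the highest number of the three, making it the weakest inhibitor in the set. Compound 3 sits closest to it, and compound 2 lies far lower.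

Compound 4 `Cn1cncc1C(O)(c1ccc(C(=O)O)cc1)c1cc2cc([N+](=O)[O-])cc(-c3ccccc3)c2o1` keeps the core of compound 1 but has carboxy in place of nitro on an aromatic carbon, para to a large group (carboxy in place of nitro on an aromatic carbon). Within the data shown here, no measured compound carries a carboxy group, and no measured pair isolates this change, so the forecast is uncertain. The expected step is toward weaker inhibition (a 3.3-fold higher number from compound 1 to compound 4 (0.52 log units; beyond the scatter)). The expected value for compound 4 is 1800 nM (estimated range 400 nM to 8000 nM).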

Compound 4, half-maximal inhibitory concentration: > 10000 nM
Compound 4 gave a limit, no number (the forecaster's own chance of this, stated with the estimate: 10%); at least 5.5-fold (0.74 log units) between middle value and limit.
By their numbers in this assay, from the lowest: compound 2; then compound 3; then compound 1. At a limit, above all of these: compound 4.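

Among these compounds, this is the first pair that isolates a single change at this place on the ring, and going from 4-nitrophenyl to 4-carboxyphenyl weakens inhibition greatly: an at least 18-fold higher number from compound 1 to compound 4 (1.26 log units; beyond the scatter). Compound 4 gives a limit, not a number: the limit of > 10000 nM in this assay, at which 1 of the 4 values shown sits. Nitro and carboxy hold equally many heavy atoms, so a swap that leaves that count unchanged can still separate two compounds widely.

The compounds shown leave open how a methyl ester or a primary amide would behave at this place. They also leave open how a nitrile here would compare with nitro on the otherwise unchanged core of compound 1.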